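This account rests on a few compounds, and the source may have more. Where it says the series, first, only, none or still open, it means among the compounds named here.

Measured so far:
compound 1, `CN1CCc2oc(=O)n(C(=O)NCCCCc3ccccc3)c2C1`: 516 nM
compound 2, `O=C(NCCCCc1ccccc1)n1c2c(oc1=O)CNCC2`: 340 nM
compound 3, `CN1CCC(c2ccc3c(c2)oc(=O)n3C(=O)NCCOCc2ccccc2)CC1`: 215 nM

In an assay on HEK293 cells for inhibition of acid ceramidase (Homo sapiens), read by fluorescence, with stated times of 10 min and 3 h (on this read-out higher numbers stand for weaker inhibition and lower numbers for stronger inhibition), compound 1 gives 516 nM, the highest of the three numbers. Compound 2, with 340 nM, lies within the usual scatter of compound 1, so the two cannot be ranked against each other. Compound 3, with 215 nM, gives a number lower than that of compound 1 by more than the scatter, and compound 3 is the only one of the three that stands apart from compound 1 in this way. Within the data shown here, no one-place step between measured compounds is available, so the effect of any single change on the shared core of compound 1 is unknown from these data.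

Compound 4, `O=C(NCCCCc1ccccc1)n1c2c(oc1=O)CCN(Cc1ccccc1)C2`, differs from compound 1 by one change:
phenyl in place of hydrogen on a saturated chain carbon bound to an amine nitrogen in a ring
The series gives no measured guide for this kind of change. A small step, if any, is expected, more likely toward a lower number than a higher one, and possibly within the scatter: a 1.5-fold lower number from compound 1 to compound 4 (0.17 log units; within the scatter) is the estimate. Compound 4 is accordingly expected to give 350 nM in this assay, with a range from 120 nM to 1000 nM.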

Compound 4, half-maximal inhibitory concentration: 436 nM
Compound 4: middle estimate off by 1.2-fold (0.10 log units), on the low side; low and high end bracket the measured number.
By their numbers in this assay, from the lowest: compounds 3, 2, 4 and 1 (each within the scatter of the next, the first and the last beyond it).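

Among these compounds, the one-place step from methyl to benzyl, with phenyl in place of hydrogen on a saturated chain carbon bound to an amine nitrogen in a ring, gives in this assay a 1.2-fold lower number from compound 1 to compound 4 (0.07 log units; within the scatter) and so offers the series its only direct reading at this place. Adding one six-membered aromatic ring of carbon only here therefore produces no change that can be separated from the scatter of this read-out. No supporting measurement is available to explain this result.

As far as these compounds go, whether a different group at this place, such as an ethyl group, a longer chain ending in phenyl, or a carboxylic acid, would give a number beyond the scatter from that of compound 1 remains open. Also open, from the compounds shown here alone, is whether an amine or a methoxy group on the phenyl of the benzyl group would shift the number.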